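Moving the carbamoyl linker into a carbamate on the shared core

The source may hold more compounds than are shown below. What is called first, only, known or untested is meant among the compounds shown, and "the series" means these compounds.

Compound 1 `Cc1cc(C(=O)NC(C)C)nn1Cc1cc(Cl)ccc1OCc1ccccc1`: 126 nM
Compound 2 `Cc1cc(C(=O)NCc2ccccn2)nn1Cc1cc(Cl)ccc1OCc1ccccc1`: 25.1 nM

Of the compounds shown here, two have been measured in an assay on CHO-K1 cells for displacement of a labelled ligand from prostaglandin E2 receptor EP1 subtype (Homo sapiens); a lower number here means a stronger inhibitor, a higher number a weaker inhibitor. Within the data shown here, compound 1 gives the higher of the two numbers; the only other compound, compound 2, sits at a stronger value, the change being a 5.0-fold lower number from compound 1 to compound 2 (0.70 log units; beyond the scatter). That step swaps the group on the amide-type nitrogen and leaves the carbamoyl attachment to the core untouched.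

Compound 3 `Cc1cc(NC(=O)OCC(C)C)nn1Cc1cc(Cl)ccc1OCc1ccccc1` is the compound not yet measured. Relative to compound 1 the change is (isobutoxycarbonyl)amino in place of isopropylcarbamoyl on an aromatic carbon. Here the attachment itself is altered: the carbamoyl group on the aromatic carbon is replaced by an amino group carrying an isobutoxycarbonyl, so the nitrogen now sits directly on the ring and the carbonyl is turned around. Among the measured compounds shown here, no measured step touches this kind of change, since the single step from compound 1 to compound 2 only varies the substituent on the amide nitrogen. The expectation for compound 3 in this assay therefore rests on compound 1 alone, with a wide range and no clear direction: the estimated step is a 1.6-fold higher number from compound 1 to compound 3 (0.20 log units; within the scatter). Compound 3 is estimated at 200 nM, between 50 nM and 800 nM.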

Compound 3, half-maximal inhibitory concentration: 25.1 nM
Compound 3: middle estimate off by 8.0-fold (0.90 log units), on the high side, and the stated range ends above it.
By their numbers in this assay, from the lowest: compounds 2 and 3 (each within the scatter of the next); then compound 1.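

In this assay, the attachment on the aromatic carbon can be turned around without loss: (isobutoxycarbonyl)amino in place of isopropylcarbamoyl gives a stronger value (a 5.0-fold lower number from compound 1 to compound 3 (0.70 log units; beyond the scatter)). This position therefore accepts a nitrogen placed directly on the ring, not only a carbonyl attached there. Compared with the ((pyridin-2-yl)methyl)carbamoyl group of compound 2, the same (isobutoxycarbonyl)amino group gives an equivalent result (no change at the digits printed from compound 2 to compound 3 (within the scatter)), so a substituent with no ring matches the pyridine-bearing amide here, and no data shown explain this.

Going by these compounds, the step to compound 3 changes both the direction of the linker and the size of the chain, so the share of each in the stronger value remains open; an (isopropoxycarbonyl)amino group on the same carbon would separate the two. On these data alone, it is also open whether the two favourable changes add together, which a ((pyridin-2-yl)methoxycarbonyl)amino group at this position would test.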